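Fluoro for ethyl on a pyridin-4-yl core

This account rests on a few compounds, and the source may have more. Where it says the series, first, only, none or still open, it means among the compounds named here.

Measured so far:
Compound 1, `Fc1cccc(Nc2nccc(-c3ccccn3)n2)c1`, gives 1000 nM in a functional assay for inhibition, with Homo sapiens as the target; a higher number here means a weaker inhibitor, a lower number a stronger inhibitor.
Compound 2, `CCc1cccc(Nc2nccc(-c3ccccn3)n2)c1`, gives 1400 nM.
Compound 3, `CCc1cccc(Nc2nccc(-c3ccncc3)n2)c1`, gives 10600 nM.

The change from compound 2 to compound 1 is fluoro in place of ethyl on an aromatic carbon, and it made a 1.4-fold lower number from compound 2 to compound 1 (0.15 log units; within the scatter). The two cores differ as pyridin-4-yl in place of pyridin-2-yl on an aromatic carbon, with a 7.6-fold higher number from compound 2 to compound 3 (0.88 log units; beyond the scatter), so compound 3 stands at the highest of the three numbers.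

Compound 4, `Fc1cccc(Nc2nccc(-c3ccncc3)n2)c1`, differs from compound 3 by fluoro in place of ethyl on an aromatic carbon. This is the same change, at a place described in the same words, as the one from compound 2 to compound 1, and it occurs twice among these compounds. The step from compound 3 to compound 4 is expected to be a 1.4-fold lower number from compound 3 to compound 4 (0.14 log units; within the scatter), a small one, because a 1.4-fold lower number from compound 2 to compound 1 (0.15 log units; within the scatter) was within the scatter. Compound 4 is therefore estimated at 7600 nM, with a range from 3500 nM to 16000 nM.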

Compound 4, half-maximal inhibitory concentration: 700 nM
Compound 4: the middle estimate sits 11-fold (1.04 log units) above what was measured; the whole stated range lies above it.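

In this assay, fluoro in place of ethyl gave a 15-fold lower number from compound 3 to compound 4 (1.18 log units; beyond the scatter), and this step did not carry over in size from the other core: the same change on two cores in this assay, a 1.4-fold lower number (0.15 log units; within the scatter) from compound 2 to compound 1 and a 15-fold lower number (1.18 log units; beyond the scatter) from compound 3 to compound 4, 11-fold (1.03 log units) apart, beyond the scatter of two such steps. Pyridin-4-yl in place of pyridin-2-yl gave a 1.4-fold lower number from compound 1 to compound 4 (0.15 log units; within the scatter), which likewise differs from the same change made with ethyl present: the same change on two cores in this assay, a 7.6-fold higher number (0.88 log units; beyond the scatter) from compound 2 to compound 3 and a 1.4-fold lower number (0.15 log units; within the scatter) from compound 1 to compound 4, 11-fold (1.03 log units) apart, beyond the scatter of two such steps. Among these four compounds, then, the size of either step depends on the group at the other place, but a single such pair does not show how general this is or what lies behind it.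

Going by these compounds, it remains open whether an amine, a methoxy group or a longer chain in place of ethyl would follow compound 3 or compound 4 on either core.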